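The source may report more compounds than this note shows. Statements on the series, on what has been measured and on what is new or still open speak of the compounds shown alone.

Compound 1 `N/C(=N\NC(=S)N1CCCCC1)c1ccccn1` gives 38.6% in a functional assay on MCF7 cells (Homo sapiens) for cytotoxicity, read by MTT assay, with a stated time of 72 h, tested at 3 uM; a higher number here means more inhibition of growth at the concentration tested, a lower number less inhibition of growth.
Compound 2 `Cc1cccc(/C(N)=N/NC(=S)N2CCCC2)n1` gives 26.6% in this assay.

Of these two numbers, compound 2 holds the lower one; the nearest number, that of compound 1, lies above it by more than the usual scatter of this measurement. Compound 3 `N/C(=N\NC(=S)N1CCCC1)c1ccccn1` differs from compound 2 in one place: hydrogen in place of methyl on an aromatic carbon. Going by the values given here, no pair of measured compounds isolates this change, so its effect is uncertain, and a shift of modest size is expected, most likely upward but possibly within the scatter. The step from compound 2 to compound 3 is estimated as a number 6.4 percentage points higher from compound 2 to compound 3 (within the scatter). Compound 3 is expected to give about 33%, between 18% and 48%.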

Compound 3, percent growth inhibition at one concentration: 49.8%
Beside the measured number, compound 3's estimate is 16.8 percentage points below it; the measured number lies above the stated range.
By their numbers in this assay, from the lowest: compound 2; then compound 1; then compound 3.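

In this assay, taking the methyl off the aromatic carbon next to the ring nitrogen gives a number 23.2 percentage points higher from compound 2 to compound 3 (beyond the scatter), which shows that this one carbon atom on the ring can clearly change growth inhibition. Replacing piperidin-1-yl with pyrrolidin-1-yl on the thiocarbonyl carbon gives a number 11.2 percentage points higher from compound 1 to compound 3 (beyond the scatter), so the group at that second place matters as well. No evidence here explains either step.

As far as these compounds go, whether a chlorine atom or a longer chain on the aromatic carbon would also lower the number remains open. So does what an open-chain diethylamino group would do on the thiocarbonyl carbon.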